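Methoxy to Ethyl on the Amine Chain of Compound 1

The source may report more compounds than this note shows. Statements on the series, on what has been measured and on what is new or still open speak of the compounds shown alone.

Measured so far in an assay on isolated protein for inhibition of Calpain-1 catalytic subunit (Homo sapiens), read by fluorescence, with a stated time of 60 min; a lower number here means a stronger inhibitor, a higher number a weaker inhibitor:
compound 1, `COCCN/C(=C1/N=CN(CCOC)C1=O)c1cc2ccccc2[nH]1`, 460 nM
compound 2, `COCCN/C(=C1/N=C(C)N(CCOC)C1=O)c1cc2ccccc2[nH]1`, 20 nM
compound 3, `COCCN/C(=C1/N=C(c2ccccc2)N(CCOC)C1=O)c1cc2ccccc2[nH]1`, reported only as a limit, > 1000 nM

Compound 1 holds the highest of the two numbers actually read; compound 2 sits well below it, a 23-fold lower number from compound 1 to compound 2 (1.36 log units; beyond the scatter). Compound 3 stops at the assay limit (the limit of > 1000 nM in this assay, at which 1 of the 3 values shown sits). The steps of an at least 2.1-fold higher number from compound 1 to compound 3 (0.33 log units; beyond the scatter) and an at least 50-fold higher number from compound 2 to compound 3 (1.69 log units; beyond the scatter), like the first, all change the group on the carbon with a double bond to nitrogen.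

Compound 4, `CCCCN/C(=C1/N=CN(CCOC)C1=O)c1cc2ccccc2[nH]1`, differs from compound 1 elsewhere: ethyl in place of methoxy on a saturated chain carbon, two bonds along the chain from an amine nitrogen. Going by the values given here, none of the measured steps touches this chain, so no step beyond the scatter is expected. Compound 4 is therefore estimated at 500 nM, within 150 nM to 1600 nM, implying a 1.1-fold higher number from compound 1 to compound 4 (0.04 log units; within the scatter).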

Compound 4, half-maximal inhibitory concentration: 350 nM
For compound 4 the middle estimate is 1.4-fold (0.15 log units) above the measured one; low and high end bracket the measured number.
By their numbers in this assay, from the lowest: compound 2; then compounds 4 and 1 (each within the scatter of the next). At a limit, above all of these: compound 3.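

Ethyl in place of methoxy on a saturated chain carbon, two bonds along the chain from an amine nitrogen, gives a 1.3-fold lower number from compound 1 to compound 4 (0.12 log units; within the scatter). This is the only reading on this chain among the compounds shown: the steps at the carbon with a double bond to nitrogen went beyond the scatter, whereas losing the hydrogen-bond acceptor of methoxy here does not. Nothing measured here accounts for this result.

From the compounds shown here alone, whether an amine, a carboxylic acid or a longer chain at this place would leave the number unchanged remains open. So does whether the same change would behave alike on compound 2.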